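The source may hold more compounds than are shown below. What is called first, only, known or untested is meant among the compounds shown, and "the series" means these compounds.

Compound 2, `CC(C)(C)Cn1cc2c(Cl)nc(NC(=O)c3ccccc3)nc2n1`, is measured in a functional assay on CHO cells for antagonist activity at adenosine receptor A2b (Homo sapiens), read by 33P incorporation, with a stated time of 20 min, in the presence of a further agent that is not named here; on this read-out higher numbers stand for weaker inhibition and lower numbers for stronger inhibition. In this assay compound 2 gives >= 10000 nM, which is a limit of the assay rather than a number. Compound 1, `CCOC(=O)c1nc(NC(=O)c2ccc(C)cc2)nc2nn(CC(C)(C)C)cc12`, gives > 20000 nM in this assay, again a limit and not a number. Compound 3, `CC(C)n1cc2c(Cl)nc(NC(=O)c3ccccc3)nc2n1`, gives > 20000 nM in this assay, also a limit. Going by the values given here, the only change between two measured compounds, a step that the two limits leave unreadable from compound 2 to compound 3, puts isopropyl in place of neopentyl on an aromatic nitrogen, and the two limits leave its size unreadable. Every value shown sits at a limit: the limit of > 20000 nM in this assay, at which 2 of the 3 values shown sit, and (the limit of >= 10000 nM in this assay, at which 1 of the 3 values shown sits). Compound 4, `Cc1ccc(C(=O)Nc2nc(Cl)c3cn(CC(C)(C)C)nc3n2)cc1`, differs from compound 2 by methyl in place of hydrogen on an aromatic carbon. Among the compounds with values here, no measured step concerns this change, and no measured compound reaches a number. The step expected is a step that the limit leaves unreadable from compound 2 to compound 4, none beyond the scatter. Compound 4 is expected to remain at a limit as well. The estimate for compound 4 in this assay is 20000 nM, with a range from 5000 nM to 60000 nM.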

Compound 4, inhibition constant: > 10000 nM
Compound 4: only a limit was reported; the forecaster's own chance of this, stated with the estimate: 85%; the middle value does not contradict the limit.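

In this assay compound 4 gives > 10000 nM, which is a limit and not a number. The steps to compound 4 from compound 1 and from compound 2 cannot be read. The compounds shown leave open how strongly any of them inhibits, and whether the added methyl changes that at all.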